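This account rests on a few compounds, and the source may have more. Where it says the series, first, only, none or still open, it means among the compounds named here.

Three compounds on the shared core have numbers in a functional assay on HL-60 cells (Homo sapiens) for inhibition; a higher number here means a weaker inhibitor of growth, a lower number a stronger inhibitor of growth. Compound 1 (`C=C(C)C(=O)c1ccc(OCc2nc(C)no2)cc1C`) gives 3820 nM, compound 2 (`C=C(C)C(=O)c1ccc(OCc2nc(-c3ccccc3)no2)cc1C`) gives 6700 nM, and compound 3 (`C=C(C)C(=O)c1ccc(OCc2nc(-c3ccc(C(F)(F)F)cc3)no2)cc1C`) gives 3200 nM. The values of compound 1 and compound 3 lie within the scatter of each other, so compound 3 stands level with compound 1 and is separated only from compound 2.

Compound 4 (`C=C(C)C(=O)c1ccc(OCc2nc(-c3ccc([N+](=O)[O-])cc3)no2)cc1C`) has not yet been measured. Its difference from compound 3 is nitro in place of trifluoromethyl on an aromatic carbon.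

Among the measured compounds shown here, no measured step exchanges these two groups directly. The most relevant one is the step in which trifluoromethyl enters, a 2.1-fold lower number from compound 2 to compound 3 (0.32 log units; beyond the scatter), which is only just beyond the scatter. The other step, a 1.8-fold higher number from compound 1 to compound 2 (0.24 log units; within the scatter), stays within it. Both are small, and neither gives a direction for the exchange at hand. With compound 3 at 3200 nM as the starting point, no change beyond the scatter is expected in this assay. The estimated step is a 1.1-fold higher number from compound 3 to compound 4 (0.04 log units; within the scatter), and it is expected to stay within the scatter. For compound 4 the expected value is 3500 nM, with an estimated range of 1700 nM to 7500 nM.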

Compound 4, concentration for 50% growth inhibition: 6100 nM
Compound 4: the middle estimate sits 1.7-fold (0.24 log units) below what was measured; the range from low to high includes it.
By their numbers in this assay, from the lowest: compounds 3, 1, 4 and 2 (each within the scatter of the next, the first and the last beyond it).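

Nitro in place of trifluoromethyl, on an aromatic carbon para to a large group, exchanges one substituent for another directly at this position, and in this assay it gives a 1.9-fold higher number from compound 3 to compound 4 (0.28 log units; within the scatter). Nitro in place of hydrogen at the same position gives a 1.1-fold lower number from compound 2 to compound 4 (0.04 log units; within the scatter), in contrast to trifluoromethyl in place of hydrogen, which gives a 2.1-fold lower number from compound 2 to compound 3 (0.32 log units; beyond the scatter), while the whole 4-nitrophenyl in place of methyl gives a 1.6-fold higher number from compound 1 to compound 4 (0.20 log units; within the scatter), so none of the three new steps separates compound 4 from its neighbours, and the trifluoromethyl step remains the only single-place step in the series beyond the scatter. No data are available here that bear on a cause for these steps.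

Open, from the compounds shown here alone, is whether an amine or a carboxylic acid on this aromatic carbon would give a step beyond the scatter in this assay, or would stay as close to compound 3 as nitro does. Also open, going by these compounds, is whether a longer chain in place of the methyl of compound 1 would separate from that compound, and whether the small trifluoromethyl step would hold on repeated measurement.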